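Adding a Chloro Group to the Second Phenyl Ring

The source may hold more compounds than are shown below. What is called first, only, known or untested is meant among the compounds shown, and "the series" means these compounds.

Measured so far:
- Compound 1 `Clc1ccc(C2CC(c3ccccc3)=NN2c2ccc(-c3ccccc3)nn2)cc1`: 100000 nM
- Compound 2 `Fc1ccc(C2CC(c3ccccc3)=NN2c2ccc(-c3ccccc3)nn2)cc1`: 10000 nM

Among the measured compounds shown here, in a functional assay on Caco-2 cells (Homo sapiens) for antiproliferative activity, read by MTT assay, with a stated time of 24 h (a higher number here means a weaker inhibitor, a lower number a stronger inhibitor), compound 2 stands with the lowest of the two numbers; its nearest neighbour is compound 1, and the only step on record runs between them: a 10-fold lower number from compound 1 to compound 2 (1.00 log units; beyond the scatter). Compound 3 `Fc1ccc(C2CC(c3ccc(Cl)cc3)=NN2c2ccc(-c3ccccc3)nn2)cc1` keeps everything of compound 2 and differs in one place: chloro in place of hydrogen on an aromatic carbon. For the measured compounds named here, this new chloro sits on the other phenyl ring of the core, a place where no measured step exists, so the step from compound 1 to compound 2 touches it only loosely, as a sign that a halogen on a phenyl ring can shift this assay noticeably. Going by the values given here, with no direct precedent, the expectation for compound 3 is a step of modest size or none beyond the scatter: a 1.5-fold higher number from compound 2 to compound 3 (0.18 log units; within the scatter). Compound 3 is therefore estimated at 15000 nM, within a range from 5000 nM to 50000 nM.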

Compound 3, half-maximal inhibitory concentration: > 100000 nM
Compound 3: a limit, no number; the forecaster's own chance of this, stated with the estimate: 15%; middle value at least 6.6-fold (0.82 log units) from the limit.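

Phenyl to 4-chlorophenyl is the first change shown at this position of the shared core, and in this assay it gives an at least 10-fold higher number from compound 2 to compound 3 (1.00 log units; beyond the scatter). This position is therefore not indifferent to substitution: a single chloro here moves the result beyond the scatter, towards weaker activity, whereas the earlier step between compound 1 and compound 2 involved only the halogen on the other phenyl ring. The value of compound 3 is a limit and not a number, so the step has a lower bound but no exact size: the limit of > 100000 nM in this assay, at which 1 of the 3 values shown sits.

From the compounds shown here alone, it remains open whether this drop belongs to chloro itself or would also follow from another group in the same place, such as a fluoro, a methyl, a methoxy or an amine. Going by these compounds, it is also open whether the same change would act alike on compound 1, which carries chloro instead of fluoro.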